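Replacing the cyclopropylmethyl side chain of compound 2

The source may hold more compounds than are shown below. What is called first, only, known or untested is meant among the compounds shown, and "the series" means these compounds.

Measured values in a functional assay on cells (T-cell, Homo sapiens) for inhibition, read by scintillation counting and thymidine incorporation, with stated times of 60 min and 3 days; a higher number here means a weaker inhibitor, a lower number a stronger inhibitor:
- compound 1 `COc1ccc(-c2cc3c(N[C@H](CO)CC(C)C)c(C(N)=O)cnn3c2)cn1` gives 190 nM
- compound 2 `COc1ccc(-c2cc3c(N[C@H](CO)CC4CC4)c(C(N)=O)cnn3c2)cn1` gives 290 nM
- compound 3 `COc1ccc(-c2cc3c(NC(CO)[C@H](O)C4CC4)c(C(N)=O)cnn3c2)cn1` gives 4800 nM; 500 nM (2 entries)

Among the compounds with values here, of the two compounds with a single number, compound 2 gives 290 nM, and it cannot be separated from its only measured neighbour: the step is a 1.5-fold higher number from compound 1 to compound 2 (0.18 log units; within the scatter). Compound 4 `COc1ccc(-c2cc3c(NC(CO)CO)c(C(N)=O)cnn3c2)cn1` is the next structure to consider, and it differs from compound 2 at one place: 2-hydroxy-1-(hydroxymethyl)ethyl in place of 1-(cyclopropylmethyl)-2-hydroxyethyl on a nitrogen on an aromatic ring. The cyclopropyl ring is lost, and a second hydroxyl-bearing arm takes its place.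

The measured step gives little guidance here, as it swaps one chain end for another and keeps the chain's carbon character. Compound 3 is closer, as it also carries an extra hydroxyl on the chain, but its entries disagree: the several entries of compound 3 in this assay, 4800 nM; 500 nM (2 entries). Its upper entry lies well above the value of compound 2, while the spread leaves the size of any effect open. A move towards a higher number in this assay is therefore expected, with a wide margin: a 5.2-fold higher number from compound 2 to compound 4 (0.71 log units; beyond the scatter). The estimated value for compound 4 is 1500 nM, with an expected range from 400 nM to 6000 nM.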

Compound 4, half-maximal inhibitory concentration: 11000 nM
Compound 4: the middle estimate sits 7.3-fold (0.87 log units) below what was measured; the whole stated range lies below it.
By their numbers in this assay, from the lowest: compounds 1 and 2 (each within the scatter of the next); then compound 4.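

In this assay, within the data shown here, this is the first change at this position that moves the number beyond the scatter: a 38-fold higher number from compound 2 to compound 4 (1.58 log units; beyond the scatter) (large), and the same replacement starting from the other side chain gives a 58-fold higher number from compound 1 to compound 4 (1.76 log units; beyond the scatter) (large). The 1-(cyclopropylmethyl)-2-hydroxyethyl and 1-(hydroxymethyl)-3-methylbutyl groups could not be separated from each other, whereas 2-hydroxy-1-(hydroxymethyl)ethyl stands well apart from both, so the position accepts an exchange between those two chain ends but not this replacement. Compound 4 gives 11000 nM, and both entries of compound 3, which keeps the cyclopropyl ring and carries an extra hydroxyl, are lower numbers, but they are too far apart to give the size of any contribution from the ring: the several entries of compound 3 in this assay, 4800 nM; 500 nM (2 entries).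

The step removes the cyclopropyl ring and adds a second hydroxyl in a single change, so the compounds shown do not tell how much of the loss belongs to either part. They also leave open how the position would respond to a methoxymethyl arm, an amine or a longer chain in place of the second hydroxymethyl arm.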